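Swapping the ring on a carbonyl carbon

This account rests on a few compounds, and the source may have more. Where it says the series, first, only, none or still open, it means among the compounds named here.

Among the measured compounds shown here, in a physicochemical assay for lipophilicity, read by HPLC, measured as chromatographic lipophilicity, at pH 7.4 (on this read-out higher numbers stand for higher lipophilicity and lower numbers for lower lipophilicity), compound 1 (`O=C(C1CCOC1)N1N=CCC1c1ccccc1`) gives 3 and stands highest of the two numbers so far. Compound 2 (`CC(C)(C)C(=O)N1CCNCC1c1ccccc1`) gives 2.5 and lies lower by more than the usual scatter. Compound 3 (`O=C(c1cccnc1)N1N=CCC1c1ccccc1`) keeps the core of compound 1 but carries pyridin-3-yl in place of oxolan-3-yl on a carbonyl carbon. For the measured compounds named here, no measured pair shows what this swap does, so any expectation is loose. The estimated step of a number 0.10 log units higher from compound 1 to compound 3 (within the scatter) is small and expected to stay within the usual scatter. The value expected for compound 3 is 3.1 with an estimated range from 2.6 to 3.6 for now.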

Compound 3, distribution coefficient: 2.7
Compound 3: middle estimate off by 0.40 log units, on the high side; the measured number falls inside the stated range.
By their numbers in this assay, from the lowest: compounds 2, 3 and 1 (each within the scatter of the next, the first and the last beyond it).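

At this place, on a carbonyl carbon, pyridin-3-yl in place of oxolan-3-yl gives a number 0.30 log units lower from compound 1 to compound 3 (within the scatter) in this assay. On the shared core, then, a six-membered aromatic ring and a five-membered non-aromatic ring cannot be told apart on this read-out. Nothing on hand explains why the two read alike. Still open, on these data alone, is whether an open-chain amine or a carboxylic acid on the same carbonyl carbon would also stay within the scatter of compound 1. The same swap on another core is also untested here.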